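From a Methoxy Group to an Amide Chain: Expected Cytotoxicity

The source may hold more compounds than are shown below. What is called first, only, known or untested is meant among the compounds shown, and "the series" means these compounds.

Of the compounds shown here, three sharing one core have been tested in an ADME assay on MDBK cells (Bos taurus) for cytotoxicity, read by MTT assay, with a stated time of 96 h; on this read-out lower numbers stand for higher toxicity in this test and higher numbers for lower toxicity in this test. Compound 1 `O=[N+]([O-])c1ccc(-c2nc3cc(C(F)(F)F)ccc3[nH]2)cc1` carries a nitro group and, in this assay, compound 1 gives 6000 nM. Compound 2 `CCC(=O)Nc1ccc(-c2nc3cc(C(F)(F)F)ccc3[nH]2)cc1` carries a propanoylamino group instead; in this assay compound 2 reaches only the limit > 100000 nM, which is a boundary of the measurement and not a number. Compound 3 `COc1ccc(-c2nc3cc(C(F)(F)F)ccc3[nH]2)cc1` carries a methoxy group, and in this assay compound 3 also reaches only the limit > 100000 nM. Compound 3 therefore stands at the upper edge of what the test can report, where (the limit of > 100000 nM in this assay, at which 2 of the 3 values shown sit).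

Compound 4 `CCN(CC)CC(=O)Nc1ccc(-c2nc3cc(C(F)(F)F)ccc3[nH]2)cc1` differs from compound 3 by a single change: (((diethylamino)methyl)carbonyl)amino in place of methoxy on an aromatic carbon. Going by the values given here, two measured steps bear on this. Going an at least 16-fold higher number from compound 1 to compound 2 (1.22 log units; beyond the scatter) and going an at least 16-fold higher number from compound 1 to compound 3 (1.22 log units; beyond the scatter) both moved the number up to the limit, so an amide-bearing compound and the methoxy compound sit together there; the step that the two limits leave unreadable from compound 2 to compound 3 cannot be sized. Since compound 2 holds an amide and already sits at > 100000 nM, compound 4 is expected to remain at or near that limit, with no step beyond the scatter.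

Compound 4 is therefore estimated to give 100000 nM, in a range from 30000 nM to 300000 nM. This estimate is expected to mean a number no higher from compound 3 to compound 4 (the limit leaves the size open).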

Compound 4, half-maximal cytotoxic concentration: 13000 nM
Compound 4: middle estimate off by 7.7-fold (0.89 log units), on the high side; measured number below the stated range.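

In this assay, going by these compounds alone, the earlier compounds left it possible that an amide on this aromatic carbon, para to a large group, was enough to keep the number at the limit, but the end of the amide chain turns out to matter: diethylamino in place of methyl on a saturated chain carbon bound to a carbonyl carbon gives an at least 7.6-fold lower number from compound 2 to compound 4 (0.88 log units; beyond the scatter). Replacing methoxy with the whole (((diethylamino)methyl)carbonyl)amino group gives an at least 7.6-fold lower number from compound 3 to compound 4 (0.88 log units; beyond the scatter), while replacing nitro with it gives a 2.2-fold higher number from compound 1 to compound 4 (0.34 log units; beyond the scatter), so this position can also give a value that lies between the nitro compound and the limit. The two lower steps are open-ended and the step between the two limit compounds cannot be read, because their values are limits of the assay: the limit of > 100000 nM in this assay, at which 2 of the 4 values shown sit.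

The compounds shown do not separate the effect of the amine from that of the longer chain, which a plain hexanoyl amide would help to tell apart. They also leave open how a smaller dimethylamino end or a carboxylic acid at the end of the chain would read in this assay.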